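Trifluoromethyl for Fluoro on Two Different Cores

The compounds below may be only part of what the source reports. "The series", "measured", "known", "first", "only" and "open" are said of these compounds alone.

Measured compounds:
compound 1, `CC(=O)Nc1ccc(O)c(C(=O)/C=C/c2ccc(F)cc2)c1`, 68800 nM
compound 2, `CC(=O)Nc1ccc(O)c(C(=O)/C=C/c2ccc(C(F)(F)F)cc2)c1`, 15500 nM
compound 3, `COc1c(-c2cccc(F)c2)oc2ccc(NC(C)=O)cc2c1=O`, > 125000 nM

In an ADME assay on THP-1 cells (Homo sapiens) for cytotoxicity, read by flow cytometry and propidium iodide staining, with a stated time of 72 h (on this read-out higher numbers stand for weaker inhibition and lower numbers for stronger inhibition), compound 1 gives 68800 nM. Compound 2 gives 15500 nM in this assay. The two differ by trifluoromethyl in place of fluoro on an aromatic carbon, and this change brought a 4.4-fold lower number from compound 1 to compound 2 (0.65 log units; beyond the scatter). Compound 3 in this assay reaches only a limit of the assay, namely > 125000 nM; here the limit of > 125000 nM in this assay, at which 1 of the 3 values shown sits, applies, so no number is known for compound 3. How the core of compound 3 differs from the core of compound 1 is not broken down here.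

Compound 4, `COc1c(-c2cccc(C(F)(F)F)c2)oc2ccc(NC(C)=O)cc2c1=O`, has not yet been measured. It differs from compound 3 by trifluoromethyl in place of fluoro on an aromatic carbon. Going by the values given here, this is the same kind of change as the one from compound 1 to compound 2, but the place is not the same: in compound 2 the trifluoromethyl sits para to a large group, in compound 4 it sits meta to a large group. The expectation for compound 4 rests on the step from compound 1 to compound 2, a 4.4-fold lower number from compound 1 to compound 2 (0.65 log units; beyond the scatter), and on compound 3 having given only a limit, > 125000 nM. On that basis the step from compound 3 to compound 4 in this assay is estimated at an at least 2.0-fold lower number from compound 3 to compound 4 (0.31 log units; beyond the scatter). Compound 4 is therefore expected to give about 60000 nM in this assay, between 20000 nM and 200000 nM, and it may well again reach only a limit.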

Compound 4, half-maximal inhibitory concentration: 52000 nM
For compound 4 the middle estimate is 1.2-fold (0.06 log units) above the measured one, and the stated range covers the measured number.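

In this assay, trifluoromethyl in place of fluoro on an aromatic carbon lowers the number on the second core as it did on the first, giving an at least 2.4-fold lower number from compound 3 to compound 4 (0.38 log units; beyond the scatter). As far as these compounds go, the direction of the change therefore carries over from the core of compound 1 to the core of compound 3, while its size on the second core stays open: the same change on two cores in this assay, a 4.4-fold lower number (0.65 log units; beyond the scatter) from compound 1 to compound 2 and an at least 2.4-fold lower number (0.38 log units; beyond the scatter) from compound 3 to compound 4; the limit leaves it open whether they differ. This does not show that the change is worth the same on both cores, since the trifluoromethyl of compound 4 sits meta to a large group, a different place from the one it holds in compound 2, and the second step rests on a limit, so the part played by core and the part played by place cannot be told apart: the limit of > 125000 nM in this assay, at which 1 of the 4 values shown sits.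

The compounds shown leave open whether trifluoromethyl in the same place on both cores would give steps of the same size, and what number the fluoro compound on the second core would give below its limit. They also leave open how other groups in that place, such as a nitrile, a chlorine atom, an amine or a carboxylic acid, would read on either core.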